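The compounds below may be only part of what the source reports. "The series", "measured", "known", "first", "only" and "open" are said of these compounds alone.

Compound 1 `O=C(Nc1cccc(N2CCCC2=O)c1)C1CCCN(C(=O)c2cc(C(F)(F)F)cc(C(F)(F)F)c2)C1` gives 0% in an ADME assay on PC-3 cells (Homo sapiens) for cytotoxicity, read by WST assay, tested at 100 uM (a lower number here means less inhibition, a higher number more inhibition at the concentration tested (going by the name of the read-out)), level at the digits printed with compound 2 `Cc1cccc(C(=O)N2CCCC(C(=O)Nc3ccc(Cl)cc3)C2)c1`, which gives 0%; together these are the lowest of the three numbers, and compound 3 `O=C(Nc1ccc(Cl)cc1)C1CCCN(C(=O)c2cccc(-c3nccs3)c2)C1` stands furthest off at 32%. Going by the values given here, the only measured step between neighbours is a number 32 percentage points higher from compound 2 to compound 3 (beyond the scatter), a large step, but it concerns an exchange unrelated to the one now in question. Compound 4 `O=C(Nc1cccc([N+](=O)[O-])c1)C1CCCN(C(=O)c2cc(C(F)(F)F)cc(C(F)(F)F)c2)C1` differs from compound 1 by nitro in place of 2-oxopyrrolidin-1-yl on an aromatic carbon. Among the compounds with values here, no measured step covers an exchange of this kind, so nothing points to a move in either direction. Compound 4 is therefore expected to show a number 5 percentage points higher from compound 1 to compound 4 (within the scatter), nothing beyond the scatter. The estimate for compound 4 is 5%, with a range from 0% to 25%.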

Compound 4, a percentage reported as inhibition, at one concentration (the size of the read-out at that concentration, not a potency): 9%
For compound 4 the middle estimate is 4 percentage points below the measured one; the measured number falls inside the stated range.
By their numbers in this assay, from the lowest: compounds 1, 2 and 4 (each within the scatter of the next); then compound 3.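

In this assay, nitro in place of 2-oxopyrrolidin-1-yl, on an aromatic carbon meta to a large group, gives a number 9 percentage points higher from compound 1 to compound 4 (within the scatter). At this position, therefore, the ring of 2-oxopyrrolidin-1-yl can be given up without a change beyond the scatter. Nothing available explains this outcome.

As far as these compounds go, whether an amine or a carboxylic acid at this position would move the number beyond the scatter remains open. Also open, from the compounds shown here alone, is whether 1,3-thiazol-2-yl would raise the number on the core of compound 1.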